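The source may report more compounds than this note shows. Statements on the series, on what has been measured and on what is new or still open speak of the compounds shown alone.

Measured compounds:
- compound 1 `NS(=O)(=O)c1ccc(Nc2nc(N/N=C/c3ccc(C(F)(F)F)cc3)nc(Nc3ccccc3)n2)cc1`: 1870 nM
- compound 2 `Cc1nn(-c2ccccc2)cc1/C=N/Nc1nc(Nc2ccccc2)nc(Nc2ccc(S(N)(=O)=O)cc2)n1`: 1600 nM

In a functional assay on Malme-3M cells (Homo sapiens) for inhibition, read by sulforhodamine B assay, with a stated time of 48 h (on this read-out lower numbers stand for stronger inhibition of growth and higher numbers for weaker inhibition of growth), compound 2 gives 1600 nM, and compound 1 gives 1870 nM; the two numbers lie within the scatter of each other, as the step of a 1.2-fold lower number from compound 1 to compound 2 (0.07 log units; within the scatter) shows, so neither stands apart from the other on this read-out.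

Compound 3 `NS(=O)(=O)c1ccc(Nc2nc(N/N=C/c3ccccn3)nc(Nc3ccccc3)n2)cc1` differs from compound 2 in one place: pyridin-2-yl in place of 3-methyl-1-phenyl-1H-pyrazol-4-yl on a carbon with a double bond to nitrogen. Going by the values given here, the only measured step that bears on this position is the exchange of the group on the carbon with a double bond to nitrogen between compound 1 and compound 2, which gave a 1.2-fold lower number from compound 1 to compound 2 (0.07 log units; within the scatter). Because that step a 1.2-fold lower number from compound 1 to compound 2 (0.07 log units; within the scatter) stayed within the scatter, the third group at this position is expected to behave alike, with no step beyond the scatter in this assay. Compound 3 is therefore estimated at 1700 nM, within a range of 800 nM to 4000 nM, which corresponds to an expected step of a 1.1-fold higher number from compound 2 to compound 3 (0.03 log units; within the scatter).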

Compound 3, concentration for 50% growth inhibition: 1000 nM
Beside the measured number, compound 3's estimate is 1.7-fold (0.23 log units) above it, and the stated range covers the measured number.
By their numbers in this assay, from the lowest: compounds 3, 2 and 1 (each within the scatter of the next).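

At the position on a carbon with a double bond to nitrogen, this assay now covers a third group, and a much smaller one: pyridin-2-yl, with one six-membered aromatic ring, replaces the two-ring 3-methyl-1-phenyl-1H-pyrazol-4-yl, giving a 1.6-fold lower number from compound 2 to compound 3 (0.20 log units; within the scatter). The exchange for 4-(trifluoromethyl)phenyl gives a 1.9-fold lower number from compound 1 to compound 3 (0.27 log units; within the scatter), so among these three aromatic groups neither ring size nor the trifluoromethyl group separates the compounds on this read-out. No measurement is available to explain these readings.

From the compounds shown here alone, all three compounds carry an aromatic ring at this position, so it remains open whether a non-aromatic group, such as a piperidine, a carboxylic acid or a longer alkyl chain, would stay within the scatter. Going by these compounds, it is also open whether pyridin-3-yl or pyridin-4-yl would read like pyridin-2-yl.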